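A nitrophenyl amine in place of a methylphenyl amine

This account rests on a few compounds, and the source may have more. Where it says the series, first, only, none or still open, it means among the compounds named here.

Compound 1 `CCCCCCCCNc1nc(SCc2ccc(C(F)(F)F)cc2)nc2ccccc12`: 22300 nM
Compound 2 `FC(F)(F)c1ccc(CSc2nc(N3CCCCC3)c3ccccc3n2)cc1`: 28400 nM
Compound 3 `Cc1ccccc1Nc1nc(SCc2ccc(C(F)(F)F)cc2)nc2ccccc12`: 27100 nM

Three compounds share a core and a trifluoromethylbenzyl thioether and differ only in the amine attached to the core. In a functional assay on MDA-MB-231 cells (Homo sapiens) for cytotoxicity, read by MTT assay, with a stated time of 72 h (on this read-out lower numbers stand for stronger inhibition and higher numbers for weaker inhibition), compound 1 gives 22300 nM, compound 2 gives 28400 nM, and compound 3 gives 27100 nM. The three numbers cannot be told apart: a 1.3-fold higher number from compound 1 to compound 2 (0.11 log units; within the scatter), a 1.2-fold higher number from compound 1 to compound 3 (0.08 log units; within the scatter), and a 1.0-fold lower number from compound 2 to compound 3 (0.02 log units; within the scatter). Compound 3 thus sits among its neighbours, with both gaps inside the scatter.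

Compound 4 `O=[N+]([O-])c1ccc(Nc2nc(SCc3ccc(C(F)(F)F)cc3)nc3ccccc23)cc1` takes the step (4-nitrophenyl in place of 2-methylphenyl on a nitrogen on an aromatic ring). Among the measured compounds shown here, the steps that bear on it are those that swap the same amine: the change from octyl to 2-methylphenyl and from piperidin-1-yl to (2-methylphenyl)amino, both within the scatter. In this assay no step beyond the scatter is therefore expected for compound 4, so the expected change is a 1.1-fold lower number from compound 3 to compound 4 (0.04 log units; within the scatter), and compound 4 is estimated at 25000 nM with a range from 10000 nM to 60000 nM.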

Compound 4, half-maximal inhibitory concentration: 8670 nM
For compound 4 the middle estimate is 2.9-fold (0.46 log units) above the measured one, and the stated range ends above it.
By their numbers in this assay, from the lowest: compound 4; then compounds 1, 3 and 2 (each within the scatter of the next).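

The earlier amines could not be told apart in this assay, but (4-nitrophenyl)amino separates from all of them: from (2-methylphenyl)amino (a 3.1-fold lower number from compound 3 to compound 4 (0.49 log units; beyond the scatter)), from piperidin-1-yl (a 3.3-fold lower number from compound 2 to compound 4 (0.52 log units; beyond the scatter)) and from octylamino (a 2.6-fold lower number from compound 1 to compound 4 (0.41 log units; beyond the scatter)). These steps are modest, yet they show that the number can respond to a change at this place on the shared core. Replacing one aromatic ring on the nitrogen with another is enough for this, although both rings are six-membered and made of carbon only. Nothing available explains why the number falls.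

The step removes a methyl group and adds a nitro group in one move, so the compounds shown cannot say which of the two changes matters. A plain phenyl or a 4-aminophenyl group on the same nitrogen would help to separate them.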